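The compounds below may be only part of what the source reports. "The series", "measured", "known", "first", "only" and "open" are said of these compounds alone.

Among the measured compounds shown here, compound 2 `Cc1cccc(O[C@@H]2CC[C@@H](C)N(C(=O)c3ccccc3-n3nccn3)C2)n1` gives 12 nM in an assay on CHO-K1 cells for displacement of a labelled ligand from Orexin/Hypocretin receptor type 1 (Homo sapiens), read by radioligand binding (on this read-out higher numbers stand for weaker inhibition and lower numbers for stronger inhibition), the lowest of the two numbers measured so far; compound 1 `CCc1ccnc(O[C@@H]2CC[C@@H](C)N(C(=O)c3ccccc3-n3nccn3)C2)c1` gives 57 nM in this assay, and the step of a 4.8-fold lower number from compound 1 to compound 2 (0.68 log units; beyond the scatter) lies beyond the scatter. Compound 3 `Cc1cccnc1O[C@@H]1CC[C@@H](C)N(C(=O)c2ccccc2-n2nccn2)C1` differs from compound 2 by the change (3-methylpyridin-2-yl in place of 6-methylpyridin-2-yl on an oxygen on a saturated carbon), so the methyl group moves from one position of the pyridinyl ring to another while the atoms stay the same. For the measured compounds named here, the only measured step, from compound 1 to compound 2, swaps a differently placed ethyl for a methyl and so bears on this new change only loosely; it shows that where the substituent sits on this ring can shift the number by a modest amount. A step of similar size or smaller, in either direction, is therefore expected, as a 1.8-fold higher number from compound 2 to compound 3 (0.26 log units; within the scatter). Compound 3 is estimated at 22 nM in this assay, within 5 nM to 90 nM.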

Compound 3, inhibition constant: 4760 nM
Compound 3: middle estimate off by 220-fold (2.34 log units), on the low side, and the stated range ends below it.
By their numbers in this assay, from the lowest: compound 2; then compound 1; then compound 3.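

In this assay, moving the methyl group alone, with the same atoms, gives a 400-fold higher number from compound 2 to compound 3 (2.60 log units; beyond the scatter). This shows that the placement of this one methyl on the pyridinyl ring matters far more than the earlier step between compound 1 and compound 2 suggested. The 3-methylpyridin-2-yl group also falls behind the 4-ethylpyridin-2-yl group, with an 84-fold higher number from compound 1 to compound 3 (1.92 log units; beyond the scatter) on the same read-out, which makes compound 3 the weakest of the three, as its steps to both others lie beyond the scatter. No measurement shown here explains this loss.

The compounds shown leave open whether the loss belongs to the methyl itself, since a plain pyridin-2-yl group on the same oxygen does not appear among them. They also leave open how a methoxy group or a chlorine atom in place of that methyl would read.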